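The source may hold more compounds than are shown below. What is called first, only, known or untested is meant among the compounds shown, and "the series" means these compounds.

Series notes. Two carbamates on the shared core have been read in an ADME assay on RAW264.7 cells (Mus musculus) for cytotoxicity, read by MTT assay, with a stated time of 18 h; on this read-out lower numbers stand for higher toxicity in this test and higher numbers for lower toxicity in this test. Compound 1 `C=C1C(=O)OC[C@@H]1CCOC(=O)Nc1ccccc1` gives 22300 nM in this assay. Compound 2 `C=C1C(=O)OC[C@H]1CCOC(=O)Nc1cc(C(F)(F)F)cc(C(F)(F)F)c1` gives 13900 nM in this assay, and the two numbers sit within the scatter of each other, so compound 2 and compound 1 are not separated by this read-out.

Compound 3 `C=C1C(=O)OC[C@@H]1CCOC(=O)Nc1cc(C(F)(F)F)cc(C(F)(F)F)c1` is the next entry. Relative to compound 2 the change is: the two compounds have the same atoms and bonds and differ only in configuration as drawn: 1 of 1 stereo elements differ; a stereocentre at a saturated ring carbon is drawn S in compound 2 and R in compound 3. Within the data shown here, no pair of measured compounds differing only in this way exists here, so the step cannot be read from the data. Given that a drawn-configuration difference also separates compound 1 from compound 2 without a clear shift in this assay, no step beyond the scatter is expected from compound 2 to compound 3, in either direction. For compound 3 the expected step is a 1.0-fold higher number from compound 2 to compound 3 (0.00 log units; within the scatter) in this assay. Compound 3 is accordingly estimated at 14000 nM in this assay, with a range from 6000 nM to 35000 nM.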

Compound 3, half-maximal cytotoxic concentration: 12400 nM
The estimate for compound 3 lay 1.1-fold (0.05 log units) above the measured number, within the range that was stated.
By their numbers in this assay, from the lowest: compounds 3, 2 and 1 (each within the scatter of the next).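

In this assay, the change of drawn configuration at the saturated ring carbon gives a 1.1-fold lower number from compound 2 to compound 3 (0.05 log units; within the scatter), so this stereocentre does not separate the two compounds carrying the pair of trifluoromethyl groups. Compound 1 and compound 2 differ in more than one place, so they could not show this for configuration alone. The new pair isolates that single change: the fact that compounds 2 and 3 differ only in the configuration as drawn.

The compounds shown leave open whether the configuration at this carbon is equally silent on the unsubstituted phenyl carbamate of compound 1, or with other substituents on the aromatic ring. They also leave open whether a carboxylic acid or an amine on that ring, or a longer chain between the shared core and the carbamate, would move the number in this assay beyond the scatter.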